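Compound 3: an expected value after an aryl exchange

A few compounds are considered here, and "the series" means these few. Any claim that something is new, unique, unknown or untested is made for them only; others in the source may bear on it.

Compounds measured so far in a functional assay on A-431 cells (Homo sapiens) for cytotoxicity (a higher number here means that more compound is needed for the effect, a lower number that less compound is needed), are these
- compound 1 `COC1=C(C)C(=O)/C(=C(O)/C=C/c2ccc(OC)cc2)C(=O)C1(C)C` gives 9.2 ug/mL
- compound 2 `CCc1ccc(/C=C/C(O)=C2/C(=O)C(C)=C(OC)C(C)(C)C2=O)cc1` gives 12 ug/mL

Going by the values given here, on these numbers, compound 2 cannot be told apart from compound 1, its only measured neighbour. Compound 3 `COC1=C(C)C(=O)/C(=C(O)/C=C/c2cc(C)cc(C)c2)C(=O)C1(C)C` has the same atoms as compound 2, joined differently (3,5-dimethylphenyl in place of 4-ethylphenyl on a double-bonded chain carbon bound to a double-bonded chain carbon), with 3,5-dimethylphenyl in place of 4-ethylphenyl on a double-bonded chain carbon bound to a double-bonded chain carbon. Among the compounds with values here, one measured step bears on this change, an exchange of ethyl for methoxy on an aromatic carbon: a 1.3-fold higher number from compound 1 to compound 2 (0.12 log units; within the scatter). Within the data shown here, no measured compound carries 3,5-dimethylphenyl, so this guide is limited. On that single step, no change beyond the scatter is expected in this assay. The estimated step is a 1.1-fold lower number from compound 2 to compound 3 (0.04 log units; within the scatter). For compound 3 the expected value is 11 ug/mL, with an estimated range from 5 ug/mL to 24 ug/mL.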

Compound 3, concentration for half-maximal effect: 4 ug/mL
The estimate for compound 3 lay 2.8-fold (0.44 log units) above the measured number; measured number outside the range, below it.
By their numbers in this assay, from the lowest: compound 3; then compounds 1 and 2 (each within the scatter of the next).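

The aryl group on a double-bonded chain carbon bound to a double-bonded chain carbon can shift the number in this assay beyond the scatter, which the earlier exchange of ethyl for methoxy did not show: 3,5-dimethylphenyl in place of 4-ethylphenyl gives a 3.0-fold lower number from compound 2 to compound 3 (0.48 log units; beyond the scatter) and 3,5-dimethylphenyl in place of 4-methoxyphenyl gives a 2.3-fold lower number from compound 1 to compound 3 (0.36 log units; beyond the scatter) as a modest step of the same direction. Compound 2 and compound 3 have the same atoms, joined differently, so a modest step at this position arises without any change in the atoms themselves. Nothing available accounts for this step.

On these data alone, whether a single methyl, as in 3-methylphenyl, is enough for this step remains open. So does the outcome with 3,5-diethylphenyl or with an amine or a carboxylic acid on the aromatic ring.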